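The source may hold more compounds than are shown below. What is called first, only, known or untested is meant among the compounds shown, and "the series" means these compounds.

Compound 1, with the structure `CCOC(=O)/C=C(C)/C=C/CC(C)CCCC(C)(C)OC`, carries a methoxy group at one end of its chain. Compound 2, `CCOC(=O)/C=C(C)/C=C/CC(C)CCCC(C)(C)O`, is the same molecule with that methoxy turned into a hydroxy group, a change that reads (hydrogen in place of methyl on an oxygen on a saturated carbon). In a physicochemical assay for lipophilicity (on this read-out lower numbers stand for lower lipophilicity and higher numbers for higher lipophilicity), compound 1 gives 5.54, while compound 2 gives 4.65, so the step is a number 0.89 log units lower from compound 1 to compound 2 (beyond the scatter).

Compound 3, `COC(CCC(C)C/C=C/C(C)=C/C(=O)OC(C)C)C(C)(C)OC`, has a different core, with two methoxy groups on neighbouring carbons and an isopropyl ester; the difference between the two cores is not broken down here. In this assay compound 3 gives 4.75, a number close to that of compound 2 and clearly below that of compound 1.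

Compound 4, `COC(C)(C)C(O)CCC(C)C/C=C/C(C)=C/C(=O)OC(C)C`, has not yet been measured. It differs from compound 3 by hydrogen in place of methyl on an oxygen on a saturated carbon. The place of this change is described in the same words as the place of the change from compound 1 to compound 2, so it is the same change on a different core. Within the data shown here, because the earlier step was a number 0.89 log units lower from compound 1 to compound 2 (beyond the scatter), a step of similar size is expected here, namely a number 0.85 log units lower from compound 3 to compound 4 (beyond the scatter), with the uncertainty that only one earlier example of the change is available and that its core differs from the core of compound 3. Compound 4 is therefore estimated to give 3.9 in this assay, expected to fall between 3.4 and 4.4.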

Compound 4, partition coefficient: 3.86
The estimate for compound 4 lay 0.04 log units above the measured number, and the stated range covers the measured number.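

In this assay, replacing a methoxy group with a hydroxy group on the core of compound 3 gives a number 0.89 log units lower from compound 3 to compound 4 (beyond the scatter), and the same change on the core of compound 1 gives a number 0.89 log units lower from compound 1 to compound 2 (beyond the scatter), so the two steps match in direction and size and the change carried over from one core to the other in this small set. Among these compounds, this shows that a step read on one core predicted the step on the other here, but it rests on only two pairs of closely related compounds and does not show that the step would stay the same on a more distant core or at another place in the molecule. The data shown offer no measurement that explains why the change has this effect or why its size is the same on both cores.

The compounds shown leave open what an amine or a carboxylic acid would give in place of the hydroxy group, and whether an ethoxy group would give a number between those of the methoxy and hydroxy compounds. They also leave open what the ethyl ester and the isopropyl ester each contribute, since no pair shown differs in the ester alone.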